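Butoxy in Place of Propylsulfanyl: Tolerance on Akata Cells

The compounds below may be only part of what the source reports. "The series", "measured", "known", "first", "only" and "open" are said of these compounds alone.

Measured compounds:
compound 1, `CC(C)CNc1nc(N)nc2c1ncn2/C=C1/CC1(CO)CO`: > 24000 nM
compound 2, `CCCSc1nc(N)nc2c1ncn2/C=C1/CC1(CO)CO`: > 20000 nM
compound 3, `Nc1nc2c(ncn2/C=C2/CC2(CO)CO)c(=O)[nH]1`: > 20000 nM

In an ADME assay on Akata cells (Homo sapiens) for cytotoxicity, with a stated time of 7 days (a lower number here means that less compound is tolerated, a higher number that more compound is tolerated), compound 1 gives > 24000 nM, which is a limit of the assay and not a number. In this assay compound 2 gives > 20000 nM, again only a limit. Compound 3 likewise gives > 20000 nM, a limit as well. Compound 2 therefore stands at the limit of > 20000 nM in this assay, at which 2 of the 3 values shown sit, the same limit at which compound 3 sits, while compound 1 rests at the limit of > 24000 nM in this assay, at which 1 of the 3 values shown sits. Among the compounds with values here, the only step between measured compounds that differ in one place, a step that the two limits leave unreadable from compound 1 to compound 2, cannot be read because a step that the two limits leave unreadable from compound 1 to compound 2 joins two limits.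

Compound 4, `CCCCOc1nc(N)nc2c1ncn2/C=C1/CC1(CO)CO`, has not yet been measured in this assay. It differs from compound 2 as follows: butoxy in place of propylsulfanyl on an aromatic carbon. Within the data shown here, no measured step speaks directly to this exchange of propylsulfanyl for butoxy, and the one step available is unreadable, so no step beyond the usual scatter is expected in this assay in either direction. Compound 4 is therefore expected to give 25000 nM in this assay, most likely reported again as a limit, within a range from 12000 nM to 60000 nM. The step this estimate implies, a step that the limit leaves unreadable from compound 2 to compound 4, is expected to be within the scatter.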

Compound 4, half-maximal cytotoxic concentration: > 20000 nM
Compound 4 gave a limit, no number; the forecaster's own chance of this, stated with the estimate: 85%; the middle value lies beyond the limit too.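

In this assay compound 4 gives > 20000 nM, which is a limit of the assay and not a number. The steps from compound 2 to compound 4 and from compound 1 to compound 4 join limits and cannot be read. The compounds shown leave open whether butoxy, propylsulfanyl and isobutylamino differ at all in how much compound is tolerated.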